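A few compounds are considered here, and "the series" means these few. Any claim that something is new, unique, unknown or untested is made for them only; others in the source may bear on it.

Measured so far:
- compound 1, `O=C(CCCSc1nc2cc(Cl)ccc2o1)N1CCCC1`: in an ADME assay on microsomes from liver (Mus musculus) for metabolic stability, read by LC-MS, using NADPH, with a stated time of 45 min, tested at 0.5 uM (on this read-out higher numbers stand for fast clearance and lower numbers for slow clearance), compound 1 gives 125 mL/min/g
- compound 2, `CS(=O)(=O)C1CCN(C(=O)CCSc2nc3cc(Cl)ccc3o2)CC1`: in this assay compound 2 gives 2.6 mL/min/g

Compound 1 stands at the highest of the two numbers recorded; the nearest, compound 2, sits far lower, a gap that is beyond the usual scatter. Compound 2 differs from compound 1 in more than one place, so its number says nothing direct about any single change.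

The step considered is from compound 1 to compound 3, `Clc1ccc2oc(SCCCN3CCCC3)nc2c1`. The structural change is pyrrolidin-1-yl in place of (pyrrolidin-1-yl)carbonyl on a saturated chain carbon, three bonds along the chain from a sulfur. Within the data shown here, no measured pair isolates this change, so the direction of the step is not anchored by data. Compound 1 is already cleared quickly, and with nothing shown to pull it either way, a modest move toward slower clearance, or none beyond the scatter, is the working expectation: the step of a 1.8-fold lower number from compound 1 to compound 3 (0.25 log units; within the scatter) is an estimate only. For compound 3 the expected value in this assay is 70 mL/min/g, with a range from 20 mL/min/g to 200 mL/min/g.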

Compound 3, intrinsic clearance in a liver preparation (reported as CLH), per the amount of preparation that the assay uses: 10.4 mL/min/g
Beside the measured number, compound 3's estimate is 6.7-fold (0.83 log units) above it; the whole stated range lies above it.
By their numbers in this assay, from the lowest: compound 2; then compound 3; then compound 1.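

In this assay, pyrrolidin-1-yl in place of (pyrrolidin-1-yl)carbonyl on a saturated chain carbon, three bonds along the chain from a sulfur, gives a 12-fold lower number from compound 1 to compound 3 (1.08 log units; beyond the scatter). Among these compounds, this is the first step that changes one place only, and it shows that the read-out responds strongly at this position: the ring stays, the carbonyl goes, and the step lies beyond the usual scatter, which the earlier pair, differing in more than one place, could not show. No measurement available here bears on the cause of this step.

Still open, as far as these compounds go, is whether the step is particular to pyrrolidin-1-yl or also holds for other groups at this place, such as morpholin-4-yl or dimethylamino. Also open, from the compounds shown here alone, is whether the same change gives a step of similar size on a longer chain.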